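This account rests on a few compounds, and the source may have more. Where it says the series, first, only, none or still open, it means among the compounds named here.

Among the measured compounds shown here, in a functional assay on RT-112 cells (Homo sapiens) for antiproliferative activity, read by MTT assay, with a stated time of 72 h (on this read-out higher numbers stand for weaker inhibition of growth and lower numbers for stronger inhibition of growth), compound 1 (`COc1cc(Nc2ncnc3c(NC(=O)Nc4cccc(Cl)c4Cl)cccc23)cc(OC)c1`) gives 63.2 nM, while compound 2 (`COc1cc(Nc2ncnc3c(NC(=O)Nc4cc(C)cc(C)c4)cccc23)cc(OC)c1`) gives 10100 nM, the higher of the two numbers so far. The next analogue, compound 3 (`COc1cc(Nc2ncnc3c(NC(=O)Nc4ccc(Cl)c(Cl)c4)cccc23)cc(OC)c1`), carries 3,4-dichlorophenyl in place of 3,5-dimethylphenyl on an amide-type nitrogen. For the measured compounds named here, the one measured step bearing on this is a 160-fold higher number from compound 1 to compound 2 (2.20 log units; beyond the scatter), a large change beyond the scatter that swaps 2,3-dichlorophenyl for 3,5-dimethylphenyl at the same place. A large move to a lower number is therefore expected, probably not the full reverse of that step. Going by the values given here, no measured compound carries 3,4-dichlorophenyl, which leaves the size uncertain. The estimated step is a 34-fold lower number from compound 2 to compound 3 (1.53 log units; beyond the scatter). For compound 3 the estimated value is 300 nM, with an expected range of 50 nM to 2500 nM.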

Compound 3, concentration for 50% growth inhibition: 6230 nM
Beside the measured number, compound 3's estimate is 21-fold (1.32 log units) below it; measured number above the stated range.
By their numbers in this assay, from the lowest: compound 1; then compounds 3 and 2 (each within the scatter of the next).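

Two chlorines on the phenyl ring do not by themselves lower the number at this amide-type nitrogen: 3,4-dichlorophenyl in place of 3,5-dimethylphenyl gives a 1.6-fold lower number from compound 2 to compound 3 (0.21 log units; within the scatter). The chlorine arrangement matters in this pair, as the change from 2,3-dichlorophenyl to 3,4-dichlorophenyl, with the same atoms entering, gives a 99-fold higher number from compound 1 to compound 3 (1.99 log units; beyond the scatter). No evidence on the cause is at hand.

Open, going by these compounds, is whether 2,3-dimethylphenyl would keep the low number of compound 1. Also open, on these data alone, is whether a single chlorine, as in 2-chlorophenyl or 3-chlorophenyl, would do so.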